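This account rests on a few compounds, and the source may have more. Where it says the series, first, only, none or still open, it means among the compounds named here.

Three compounds have been measured in an ADME assay on RD cells (Homo sapiens) for cytotoxicity, read by MTT assay, with a stated time of 3 days; a lower number here means that less compound is tolerated, a higher number that more compound is tolerated:

compound 1 `CC[C@H](CCn1cncn1)c1ccc(F)cc1`: 110 ug/mL
compound 2 `CC[C@H](CCn1cncn1)c1ccc(C)cc1`: 85.2 ug/mL
compound 3 `CC[C@H](CCn1cncn1)c1ccc(OC)cc1`: 118 ug/mL

All three share the same core and differ only in the group on the aromatic ring. The number for compound 1 sits close to both of the others: it differs by a 1.1-fold higher number from compound 1 to compound 3 (0.03 log units; within the scatter) and by a 1.3-fold lower number from compound 1 to compound 2 (0.11 log units; within the scatter), each within the scatter, so the three compounds cannot be told apart on these results.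

Compound 4 `CCCC[C@H](CCn1cncn1)c1ccc(F)cc1` is the compound under consideration here. It differs from compound 1 by ethyl in place of hydrogen on a saturated chain carbon, three bonds along the chain from an aromatic carbon. Going by the values given here, none of the measured steps touches this place; each of them, including a 1.4-fold higher number from compound 2 to compound 3 (0.14 log units; within the scatter), is a swap on the aromatic ring and stays within the scatter. Among the compounds with values here, there is thus no measured step that speaks for a change beyond the scatter in this assay, and the expectation is for compound 4 to land near compound 1, with a step of a 1.2-fold lower number from compound 1 to compound 4 (0.06 log units; within the scatter). The estimate for compound 4 in this assay is 95 ug/mL, with a range from 55 ug/mL to 165 ug/mL.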

Compound 4, half-maximal cytotoxic concentration: 35.2 ug/mL
For compound 4 the middle estimate is 2.7-fold (0.43 log units) above the measured one; the measured number lies below the stated range.
By their numbers in this assay, from the lowest: compound 4; then compounds 2, 1 and 3 (each within the scatter of the next).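

Going by these compounds alone, the swaps on the aromatic ring among compounds 1, 2 and 3 all stayed within the scatter, so the saturated chain is the first place here where a single change clearly moves the number. In this assay, ethyl in place of hydrogen on a saturated chain carbon, three bonds along the chain from an aromatic carbon, gives a 3.1-fold lower number from compound 1 to compound 4 (0.49 log units; beyond the scatter) and is the only step shown that lies beyond the scatter, meaning that less of compound 4 is tolerated by the cells. Nothing measured here explains this drop.

The compounds shown leave open how the number follows chain length at this place, which a propyl group or a longer chain could test. On these data alone, it also remains open whether a chain ending in an amine would behave like the butyl chain of compound 4.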